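The compounds below may be only part of what the source reports. "The series", "measured", "known", "first", "only" and "open" are said of these compounds alone.

Measured compounds:
compound 1, `ClCc1cccc(Cn2cnc3ncnc(Cl)c32)c1`: in a functional assay on MCF7 cells (Homo sapiens) for cytotoxicity, read by sulforhodamine B assay, with a stated time of 48 h (on this read-out higher numbers stand for weaker inhibition of growth and lower numbers for stronger inhibition of growth), compound 1 gives 1580 nM
compound 2, `ClCc1ccc(Cn2cnc3nc(Cl)nc(Cl)c32)cc1`: in this assay compound 2 gives 4160 nM
compound 3, `ClCc1cccc(Cn2cnc3nc(Cl)nc(Cl)c32)c1`: in this assay compound 3 gives 1510 nM

Compound 1 and compound 3 share one core; compound 2 has the same atoms as compound 3 joined differently, and the difference between the two cores is not broken down here. Compound 2 stands highest of the three numbers, beyond the scatter from compound 1 and from compound 3.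

For the measured compounds named here, the one counted change is hydrogen in place of chloro on an aromatic carbon. In this assay this gave a 1.0-fold higher number from compound 3 to compound 1 (0.02 log units; within the scatter).

Compound 4, `ClCc1ccc(Cn2cnc3ncnc(Cl)c32)cc1`, is not yet measured. It differs from compound 2 by hydrogen in place of chloro on an aromatic carbon, the same change at a place described in the same words, so it occurs twice in all. The expected step of a 1.0-fold lower number from compound 2 to compound 4 (0.02 log units; within the scatter) for compound 4 is set close to flat because a 1.0-fold higher number from compound 3 to compound 1 (0.02 log units; within the scatter) lay within the scatter. Compound 4 is therefore estimated at 4000 nM in this assay, expected between 2000 nM and 8000 nM, resting on compound 2 at 4160 nM.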

Compound 4, concentration for 50% growth inhibition: 1340 nM
Beside the measured number, compound 4's estimate is 3.0-fold (0.47 log units) above it; measured number below the stated range.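

In this assay, hydrogen in place of chloro on the aromatic carbon between two ring nitrogen atoms gave a 3.1-fold lower number from compound 2 to compound 4 (0.49 log units; beyond the scatter). For the compounds shown here, the change therefore does not carry over from one core to the other with a single size: the same change on two cores in this assay, a 1.0-fold higher number (0.02 log units; within the scatter) from compound 3 to compound 1 and a 3.1-fold lower number (0.49 log units; beyond the scatter) from compound 2 to compound 4, 3.2-fold (0.51 log units) apart, beyond the scatter of two such steps This shows only that the step differs between these two pairs of compounds; with a single comparison it gives no rule for a further core, and it does not show what sets the two steps apart.

Going by these compounds alone, still open is whether an amine or a methoxy group on that same aromatic carbon would follow the step seen from compound 3 to compound 1 or the one seen from compound 2 to compound 4. Also open, going by these compounds, is whether a longer chain carrying the terminal chloro would keep the gap between the two cores, and whether that gap appears in any other cell line.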